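Swapping Phenyl for Thiophene on the Sulfonamide Side

The source may report more compounds than this note shows. Statements on the series, on what has been measured and on what is new or still open speak of the compounds shown alone.

All three measured compounds were tested in a functional assay for agonist activity at growth hormone secretagogue receptor type 1 (Homo sapiens), read by FLIPR; a lower number here means that less compound is needed, a higher number that more compound is needed for the effect:

Compound 1, `COc1ccc(N2C[C@@H](C)N[C@@H](C)C2)cc1NS(=O)(=O)c1ccc(-c2ccccn2)s1`, gives 10 nM.
Compound 2, `CC(=O)c1ccc(N2C[C@@H](C)N[C@@H](C)C2)cc1NS(=O)(=O)c1ccc(-c2ccccn2)s1`, gives 39.8 nM.
Compound 3, `COc1ccc(N2C[C@@H](C)N[C@@H](C)C2)cc1NS(=O)(=O)c1ccc(-c2ccccc2)cc1`, gives 6.31 nM.

Compound 3 gives the lowest of the three numbers in this assay. Its nearest neighbour is compound 1, whose number sits within the usual scatter, so the two cannot be ranked against each other. Compound 2 stands further away, beyond the scatter. Within the data shown here, the only single-point change among the measured compounds is a 4.0-fold higher number from compound 1 to compound 2 (0.60 log units; beyond the scatter), and it concerns the substituent on the core, not the ring attached to the sulfonamide.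

Compound 4, `COc1ccc(N2C[C@@H](C)N[C@@H](C)C2)cc1NS(=O)(=O)c1ccc(-c2cccs2)cc1`, is derived from compound 3 by one change: thiophen-2-yl in place of phenyl on an aromatic carbon. Among the measured compounds shown here, no measured step touches this position. Compound 1 and compound 3 differ in more than one place, so their values, which lie within the scatter of each other, offer only a faint hint that changes on the sulfonamide side are tolerated.

With nothing pointing either way, compound 4 is expected to show no shift beyond the scatter, a 1.1-fold higher number from compound 3 to compound 4 (0.05 log units; within the scatter). The estimate for compound 4 in this assay is 7 nM, with a likely range from 3 nM to 16 nM.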

Compound 4, half-maximal effective concentration: 3.98 nM
The estimate for compound 4 lay 1.8-fold (0.25 log units) above the measured number, and the stated range covers the measured number.
By their numbers in this assay, from the lowest: compounds 4, 3 and 1 (each within the scatter of the next, the first and the last beyond it); then compound 2.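

In this assay, thiophen-2-yl in place of phenyl, on an aromatic carbon para to a large group, gives a 1.6-fold lower number from compound 3 to compound 4 (0.20 log units; within the scatter), so the two compounds cannot be ranked against each other. Among these compounds, this is the first direct reading at this position, and it replaces the earlier faint hint: a six-membered aromatic ring of carbon only can give way to a five-membered aromatic ring containing sulfur, with one heavy atom fewer and one hydrogen-bond acceptor more by count, without a shift beyond the usual scatter. Nothing measured here explains why the number holds.

Phenyl and thiophen-2-yl are both aromatic rings, so it remains open how this position would respond to something of a different kind, such as a carboxylic acid, a primary amine or a straight butyl chain. Among the compounds shown here, it also remains open whether this swap would give a similar result with acetyl in place of methoxy on the shared core, the change that gave the one step beyond the scatter so far.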